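A few compounds are considered here, and "the series" means these few. Any claim that something is new, unique, unknown or untested is made for them only; others in the source may bear on it.

Two imines sharing one core have been tested in a functional assay on L1210 cells (Mus musculus), read by cell counting, with a stated time of 48 h; a higher number here means a weaker inhibitor, a lower number a stronger inhibitor. Compound 1 `Fc1ccc(/N=C/c2ccccc2Cl)cc1Cl` gives 6.4 ug/mL in this assay, and compound 2 `Fc1ccc(/N=C/c2ccccc2Cl)cc1` gives 6 ug/mL. Among the measured compounds shown here, the single step between them, a 1.1-fold lower number from compound 1 to compound 2 (0.03 log units; within the scatter), consists of a hydrogen in place of chloro on an aromatic carbon. Compound 2 therefore stands alongside compound 1 in this assay, the two numbers lying within the scatter of each other, so neither can be called the stronger inhibitor.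

Compound 3 `Clc1ccccc1/C=N/c1ccc(Br)cc1` has not yet been measured in this assay. It differs from compound 2 by bromo in place of fluoro on an aromatic carbon. For the measured compounds named here, the only measured step that bears on this change is the halogen-to-hydrogen step from compound 1 to compound 2, which left the number essentially where it was; it concerns a different halogen at a different place, so its guidance is limited, and nothing is known here about an exchange of one halogen for another. On that basis the expected step of no change at the digits printed from compound 2 to compound 3 (within the scatter) is none beyond the scatter. Compound 3 is accordingly estimated at 6 ug/mL in this assay, within a range from 3 ug/mL to 12 ug/mL.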

Compound 3, half-maximal inhibitory concentration: 2.1 ug/mL
For compound 3 the middle estimate is 2.9-fold (0.46 log units) above the measured one; measured number below the stated range.
By their numbers in this assay, from the lowest: compound 3; then compounds 2 and 1 (each within the scatter of the next).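

In this assay the exchange of fluoro for bromo on an aromatic carbon, para to a group of 9 heavy atoms, gives a 2.9-fold lower number from compound 2 to compound 3 (0.46 log units; beyond the scatter) and so is a modest step, the first among these compounds to lie beyond the scatter. The earlier step, a 1.1-fold lower number from compound 1 to compound 2 (0.03 log units; within the scatter) with a chloro giving way to hydrogen at a different place, had shown no change that could be told from the scatter, so it said nothing about this position; the new pair shows that the number does respond to which of these two halogens sits here. Nothing at hand explains why the number is lower with bromo than with fluoro.

The compounds shown leave open whether the number follows the halogens in any order, since a chloro or an iodo at this position would be needed to tell a trend from a single exchange. They also leave open whether anything other than a halogen is tolerated here, such as an amine, a methoxy group or a carboxylic acid, and whether the lower number of compound 3 carries over to other assays.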